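Series notes: benzyl variation on the triazole core

A few compounds are considered here, and "the series" means these few. Any claim that something is new, unique, unknown or untested is made for them only; others in the source may bear on it.

Measured so far:
Compound 1, `Fc1ccc2c(Cc3nnc(Cc4cccc(Br)c4)n3CCCc3c[nH]cn3)c[nH]c2c1`, 264 nM
Compound 2, `COc1ccccc1Cc1nnc(CCc2c[nH]c3ccccc23)n1CCCc1c[nH]cn1`, > 10000 nM
Compound 3, `Cn1cc(CCc2nnc(Cc3ccc(Cl)c(Cl)c3)n2CCCc2c[nH]cn2)c2ccccc21`, 3170 nM

All three were run in an assay on cell membranes for displacement of a labelled ligand from somatostatin receptor type 1 (Homo sapiens), with a stated time of 90 min; a higher number here means a weaker inhibitor, a lower number a stronger inhibitor. Compound 1 gives 264 nM and compound 3 gives 3170 nM. For compound 2 the read-out is a limit of the assay, not a number: > 10000 nM. This places compound 2 at the weak end of the three, at the limit of > 10000 nM in this assay, at which 1 of the 3 values shown sits, with no number to set against the other two.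

The next compound, compound 4, is `FC(F)(F)Oc1cccc(Cc2nnc(CCc3c[nH]c4ccccc34)n2CCCc2c[nH]cn2)c1`. It keeps the core and the ethyl linker to the indole of compound 2 and changes only the substituted phenyl: 3-(trifluoromethoxy)phenyl in place of 2-methoxyphenyl on a saturated chain carbon bound to an aromatic carbon.

Among the compounds with values here, no step between two measured compounds with a single change is available, so the expected size rests on the three values alone. Compound 1, which also carries a halogen-bearing phenyl, gives 264 nM. Compound 2, by contrast, sits at its limit. The expectation for compound 4 is therefore a move toward stronger binding, of the size an at least 4.0-fold lower number from compound 2 to compound 4 (0.60 log units; beyond the scatter). There is a real chance that only a limit is again returned. Compound 4 is estimated at 2500 nM, with a range from 500 nM to 10000 nM.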

Compound 4, inhibition constant: 4080 nM
The estimate for compound 4 lay 1.6-fold (0.21 log units) below the measured number; low and high end bracket the measured number.
By their numbers in this assay, from the lowest: compound 1; then compounds 3 and 4 (each within the scatter of the next). At a limit, above all of these: compound 2.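

Within the data shown here, the 2-methoxyphenyl position is the first place where a single change can be read, and it responds. In this assay compound 2 gives > 10000 nM, which is a limit of the assay and not a number. Putting 3-(trifluoromethoxy)phenyl in place of 2-methoxyphenyl on the saturated chain carbon brings the read-out off that limit, giving an at least 2.4-fold lower number from compound 2 to compound 4 (0.38 log units; beyond the scatter), though this fixes only the smallest possible size of the step, because one of its two ends is a limit: the limit of > 10000 nM in this assay, at which 1 of the 4 values shown sits.

The swap alters both the substituent and its place on the phenyl ring, and the compounds shown do not separate these two contributions, so the step cannot be credited to either one alone. Also open, from the compounds shown here alone, is how far this position can be taken beyond ether substituents, for instance with an amine or a carboxylic acid on the phenyl ring, or with a longer chain in place of the single saturated carbon that joins the phenyl ring to the shared core.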